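The compounds below may be only part of what the source reports. "The series", "measured", "known", "first", "only" and "open" are said of these compounds alone.

Compound 1 `O=C(O)c1ccc(C(=O)c2ccc(C(=O)c3ccc(Cl)cc3)cc2)cc1`: 35 nM
Compound 2 `O=C(O)c1ccc(C(=O)c2ccc(C(=O)c3ccc(Cl)c(Cl)c3)cc2)cc1`: 35 nM

In an assay on CHO cells for inhibition of 3-oxo-5-alpha-steroid 4-dehydrogenase 2 (Homo sapiens) (on this read-out lower numbers stand for stronger inhibition and higher numbers for weaker inhibition), compound 1 gives 35 nM and compound 2 gives 35 nM. Among the measured compounds shown here, compound 2 therefore stands level with compound 1, the only other measured compound, and the one measured step, no change at the digits printed from compound 1 to compound 2 (within the scatter), shows that adding a chloro on the terminal ring leaves the read-out unchanged.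

Compound 3 `O=C(O)c1ccc(C(=O)c2ccc(C(=O)C3CCCCC3)cc2)cc1` is not yet measured in this assay. It differs from compound 2 in one place: cyclohexyl in place of 3,4-dichlorophenyl on a carbonyl carbon. For the measured compounds named here, no measured step exchanges the aromatic ring on that carbonyl for a saturated one; the step from compound 1 to compound 2 concerns only a substituent on that ring and shows it tolerates an added chloro without change. That bears only loosely on the present change, which removes the ring itself, so the expectation is uncertain. A modest weakening is expected, a 2.3-fold higher number from compound 2 to compound 3 (0.36 log units; beyond the scatter), since the change goes well beyond what the measured step covers. Compound 3 is thus estimated at 80 nM, with a range from 20 nM to 400 nM.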

Compound 3, inhibition constant: 30 nM
Compound 3: the middle estimate sits 2.7-fold (0.43 log units) above what was measured, and the stated range covers the measured number.
By their numbers in this assay, from the lowest: compounds 3, 1 and 2 (each within the scatter of the next).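

In this assay, the exchange of 3,4-dichlorophenyl for cyclohexyl on this carbonyl carbon gives a 1.2-fold lower number from compound 2 to compound 3 (0.07 log units; within the scatter), and the exchange of 4-chlorophenyl for cyclohexyl gives a 1.2-fold lower number from compound 1 to compound 3 (0.07 log units; within the scatter). Among the compounds shown here, the earlier compounds showed only that the aromatic ring at this position accepts an added chloro, whereas these two steps show that the aromatic ring itself can give way to a non-aromatic six-membered carbon ring with no change beyond the scatter, and that the chlorines need not be present for the read-out to stay at this level. Nothing available here explains why the saturated and aromatic rings cannot be told apart in this read-out.

Going by these compounds, all three compounds still carry a six-membered carbon ring on this carbonyl, so it remains open whether a ring is needed there at all, or whether a methyl, an open chain such as n-butyl, or a ring carrying an amine would hold the same level. On these data alone, the carboxylic acid and the rest of the shared core are the same throughout, so their part in the read-out also remains open.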